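The source may hold more compounds than are shown below. What is called first, only, known or untested is meant among the compounds shown, and "the series" means these compounds.

Measured so far in an ADME assay on Vero cells (Chlorocebus sabaeus) for cytotoxicity, read by MTT assay, with a stated time of 48 h; a lower number here means that less compound is tolerated, a higher number that more compound is tolerated:
compound 1 `CC(C)(C)c1ccc(C(C)(C)NC(=O)c2ccc([N+](=O)[O-])o2)cc1` — > 150000 nM
compound 2 `CC(C)(NC(=O)c1ccc([N+](=O)[O-])o1)c1ccc(COc2ccc(Cl)cc2)cc1` — 120000 nM

In this assay compound 1 gives > 150000 nM, which is a limit of the assay and not a number. Going by the values given here, compound 2 gives 120000 nM, the only number among the values shown (the limit of > 150000 nM in this assay, at which 1 of the 2 values shown sits). The step of an at least 1.2-fold lower number from compound 1 to compound 2 (0.09 log units; that floor lies within the scatter) lies within the scatter.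

Compound 3 `COc1ccc(OCc2ccc(C(C)(C)NC(=O)c3ccc([N+](=O)[O-])o3)cc2)cc1` differs from compound 2 by methoxy in place of chloro on an aromatic carbon. Among the compounds with values here, no measured step covers this change, and the single step that exists, from compound 1 to compound 2, stayed within the scatter. The expected step is therefore no change at the digits printed from compound 2 to compound 3 (within the scatter), none beyond the scatter. For compound 3 the estimate in this assay is 120000 nM, in the range 60000 nM to 240000 nM.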

Compound 3, half-maximal cytotoxic concentration: > 120000 nM
Compound 3 ended at the assay's limit (the forecaster's own chance of this, stated with the estimate: 35%); the middle value sits exactly at the limit.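

In this assay, going by these compounds alone, the first change on the outer ring of the (4-chlorophenoxy)methyl group gives a number no lower from compound 2 to compound 3 (the limit leaves the size open). So chloro is not needed here to keep this number, and methoxy is tolerated at this position. Compound 3 stands at a limit of the assay, not at a number: the limit of > 120000 nM in this assay, at which 1 of the 3 values shown sits.

The step between compound 1 and compound 3 cannot be read. Open, going by these compounds, are the true size of the change from chloro to methoxy and what an amine or a carboxylic acid on this aromatic carbon would give.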